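Amide aryl exchange on the shared core: compound 2 to compound 4

The source may hold more compounds than are shown below. What is called first, only, known or untested is meant among the compounds shown, and "the series" means these compounds.

Compound 2 `Cc1ccc(NC(=O)c2cccc(/C=C3\CC(=O)N(c4ccccc4)C3=O)c2)cc1C` is one of three compounds with a value in an ADME assay on SW480 cells (Homo sapiens) for cytotoxicity, read by MTT assay, with a stated time of 72 h; a lower number here means a stronger inhibitor, a higher number a weaker inhibitor. In this assay compound 2 gives > 100000 nM, which is a limit of the assay rather than a number. Compound 1 `CCCCCN1C(=O)C/C(=C\c2cccc(C(=O)Nc3ccc(C)cc3)c2)C1=O` likewise gives only the limit > 100000 nM in this assay. Compound 3 `CCCCCN1C(=O)C/C(=C\c2cccc(C(=O)Nc3cccc(CC)c3)c2)C1=O` gives 83300 nM in this assay. For the measured compounds named here, the single measured step, an at least 1.2-fold lower number from compound 1 to compound 3 (0.07 log units; that floor lies within the scatter), sits within the scatter of repeated measurements, and the limit of > 100000 nM in this assay, at which 2 of the 3 values shown sit, shows where most of the series stands.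

Compound 4 `COc1ccc(OC)c(NC(=O)c2cccc(/C=C3\CC(=O)N(c4ccccc4)C3=O)c2)c1` differs from compound 2 in one place: 2,5-dimethoxyphenyl in place of 3,4-dimethylphenyl on an amide-type nitrogen. Going by the values given here, no measured step touches a 2,5-dimethoxyphenyl group on the amide-type nitrogen, and the only measured step, an at least 1.2-fold lower number from compound 1 to compound 3 (0.07 log units; that floor lies within the scatter), is too small to point in any direction. A step beyond the scatter is therefore not expected from compound 2 to compound 4, and the expected step of a number no higher from compound 2 to compound 4 (the limit leaves the size open) is close to nil. Compound 4 is accordingly estimated at 100000 nM in this assay, with a range from 50000 nM to 200000 nM, and most likely the assay will again report only a limit.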

Compound 4, half-maximal inhibitory concentration: > 100000 nM
Compound 4 was reported as a limit; the forecaster's own chance of this, stated with the estimate: 70%; the middle value sits exactly at the limit.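

For the compounds shown here, compound 2 and compound 4 are both reported only as limits in this assay, so no step between them can be read. The compounds shown leave open whether 2,5-dimethoxyphenyl and 3,4-dimethylphenyl on the amide-type nitrogen differ at all in this read-out.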